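The compounds below may be only part of what the source reports. "The series", "measured", "known", "first", "only" and "open" are said of these compounds alone.

Of the compounds shown here, three sharing one core have been tested for how strongly they act on cells. In a functional assay on KB cells (Homo sapiens) for cytotoxicity (on this read-out higher numbers stand for an effect only at larger amounts of compound and lower numbers for an effect already at smaller amounts), compound 1, `CCC[C@@H](OC(C)=O)C1=C(Br)/C(=C/Br)OC1=O`, gives 0.8 ug/mL. Compound 2, `CCC[C@@H](OC(C)=O)C1=C(Br)C(=C(Br)Br)OC1=O`, gives 0.3 ug/mL in this assay, while compound 3, `CCC[C@@H](OC(C)=O)C1=C(Br)[C@@](OC)(C(Br)Br)OC1=O`, gives 4.1 ug/mL. Compound 1 therefore stands with the second highest of the three numbers: its nearest neighbour is compound 2, whose number is lower by an amount beyond the usual scatter, and the furthest is compound 3, whose number is higher, again beyond the scatter.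

Compound 4, `CCC[C@@H](O)C1=C(Br)/C(=C/Br)OC1=O`, differs from compound 1 in a single place: hydrogen in place of acetyl on an oxygen on a saturated carbon. Among the compounds with values here, no pair of measured compounds shows exactly this change, so nothing here tells how it shifts the number. On that basis only a small step is expected, the number of compound 4 drifting somewhat upward from that of compound 1, with a step of a 1.9-fold higher number from compound 1 to compound 4 (0.27 log units; within the scatter) that is expected to sit close to the scatter. Compound 4 is thus estimated at 1.5 ug/mL, within a range from 0.5 ug/mL to 5 ug/mL.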

Compound 4, concentration for half-maximal effect: 0.4 ug/mL
Compound 4: middle estimate off by 3.8-fold (0.57 log units), on the high side; the whole stated range lies above it.
By their numbers in this assay, from the lowest: compounds 2, 4 and 1 (each within the scatter of the next, the first and the last beyond it); then compound 3.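

In this assay, replacing acetoxy with hydroxy on the saturated carbon gives a 2.0-fold lower number from compound 1 to compound 4 (0.30 log units; within the scatter), so this change cannot be told apart from repeat-to-repeat variation. At this position, then, the acetyl group can leave the oxygen without a measurable loss of effect on these cells, and the free hydroxy compound remains comparable to its acetylated partner. No supporting measurements are available to explain why the read-out holds across this change.

Going by these compounds, only hydrogen and acetyl have been compared on this oxygen, so it remains open whether a methyl group or a longer acyl chain, such as butanoyl, would fit the same picture. It is also unknown whether an amine in place of the hydroxy group would give a comparable number.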